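Removing the methoxy group: from compound 3 to compound 4

This account rests on a few compounds, and the source may have more. Where it says the series, first, only, none or still open, it means among the compounds named here.

Three members of the series have been measured in an in vitro functional assay on cells for agonist activity at Bombesin receptor subtype-3 (Mus musculus), read by luminescence and calcium flux; on this read-out higher numbers stand for an effect only at larger amounts of compound and lower numbers for an effect already at smaller amounts. Compound 1 `O=C(O)c1ccccc1-c1ccc(CCc2ncc(C3CCCCC3)[nH]2)cc1` carries a cyclohexyl group on the shared core, and in this assay compound 1 gives 14.7 nM. Compound 2 `N#Cc1cccc(Cc2cnc(CCc3ccc(-c4ccccc4C(=O)O)cc3)[nH]2)c1` carries a 3-cyanobenzyl group in the same place, and in this assay compound 2 gives 20 nM. Compound 3 `COc1ccccc1Cc1cnc(CCc2ccc(-c3ccccc3C(=O)O)cc2)[nH]1` carries a 2-methoxybenzyl group, and in this assay compound 3 gives 163 nM. Compound 3 stands highest of the three numbers: an 11-fold higher number from compound 1 to compound 3 (1.04 log units; beyond the scatter) and an 8.2-fold higher number from compound 2 to compound 3 (0.91 log units; beyond the scatter), whereas a 1.4-fold higher number from compound 1 to compound 2 (0.13 log units; within the scatter).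

Compound 4 `O=C(O)c1ccccc1-c1ccc(CCc2ncc(Cc3ccccc3)[nH]2)cc1` differs from compound 3 by hydrogen in place of methoxy on an aromatic carbon. Within the data shown here, no measured step strips a substituent from the benzyl group outright, so the bearing comes from the two steps that reach compound 3: an 8.2-fold higher number from compound 2 to compound 3 (0.91 log units; beyond the scatter) shows that the substituent on the benzyl ring alone moves the number well beyond the scatter, and an 11-fold higher number from compound 1 to compound 3 (1.04 log units; beyond the scatter) places compound 3 far above the cyclohexyl compound. The removal of the methoxy is therefore expected to lower the number for compound 4 in this assay, by about a 4.1-fold lower number from compound 3 to compound 4 (0.61 log units; beyond the scatter), towards the region of compound 1 and compound 2, though whether it reaches them cannot be told from three points. Compound 4 is estimated at 40 nM in this assay, with a range from 12 nM to 130 nM.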

Compound 4, half-maximal effective concentration: 11 nM
Compound 4: the middle estimate sits 3.6-fold (0.56 log units) above what was measured; the measured number lies below the stated range.
By their numbers in this assay, from the lowest: compounds 4, 1 and 2 (each within the scatter of the next); then compound 3.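

In this assay, among these compounds, a 15-fold lower number from compound 3 to compound 4 (1.17 log units; beyond the scatter) shows that the high number of compound 3 goes with the methoxy on the 2-methoxybenzyl group and not with the benzyl group as such, which the earlier steps could not separate. Two further steps stay within the scatter: a 1.8-fold lower number from compound 2 to compound 4 (0.26 log units; within the scatter), with hydrogen in place of cyano, and a 1.3-fold lower number from compound 1 to compound 4 (0.13 log units; within the scatter), with benzyl in place of cyclohexyl. Among the four groups shown at this position, only 2-methoxybenzyl therefore stands apart, while benzyl, 3-cyanobenzyl and cyclohexyl cannot be told apart; no measurement at hand accounts for the methoxy step.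

Still open, on these data alone, is whether this large step belongs to methoxy itself or would also follow from another group at the same place on the aromatic ring, such as methyl, chlorine or hydroxyl. Also open, as far as these compounds go, is whether the number stays in the same region when the benzyl group gives way to a phenethyl group or when an amine is carried on the ring.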